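Replacing the aryl end of compound 1

The source may hold more compounds than are shown below. What is called first, only, known or untested is meant among the compounds shown, and "the series" means these compounds.

Among the measured compounds shown here, in a functional assay on MIA PaCa-2 cells (Homo sapiens) for inhibition, read by MTT assay, with a stated time of 4 days (on this read-out higher numbers stand for weaker inhibition and lower numbers for stronger inhibition), compound 1 (`COc1cc(NC(C)CCCNC(=O)NNC(=O)Nc2ccc(Cl)c(C(F)(F)F)c2)c2ncccc2c1`) gives 18000 nM, the lowest number so far. Compound 2 (`COc1ccc(/C(=N/NC(=O)NCCCC(C)Nc2cc(OC)cc3cccnc23)c2ccccc2)cc1`) gives 155000 nM, a gap beyond the scatter. Compound 3 (`COc1cc(NC(C)CCCNC(=O)NNC(=O)N(CCO)CCO)c2ncccc2c1`) carries bis(2-hydroxyethyl)amino in place of (4-chloro-3-(trifluoromethyl)phenyl)amino on a carbonyl carbon. For the measured compounds named here, no measured step covers this change, so the expectation is only a judgement: a clear rise in this assay, towards weaker inhibition. The estimated step is a 5.6-fold higher number from compound 1 to compound 3 (0.74 log units; beyond the scatter). For compound 3 the expected value is 100000 nM, with an estimated range of 30000 nM to 300000 nM.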

Compound 3, half-maximal inhibitory concentration: > 250000 nM
Compound 3 gave a limit, no number; the forecaster's own chance of this, stated with the estimate: 30%; middle value at least 2.5-fold (0.39 log units) from the limit.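

In this assay, putting bis(2-hydroxyethyl)amino in place of (4-chloro-3-(trifluoromethyl)phenyl)amino on a carbonyl carbon gives an at least 13-fold higher number from compound 1 to compound 3 (1.14 log units; beyond the scatter). This is the only one-place change among the compounds shown, and it shows that the group at this position matters, with the aryl end of compound 1 on the side of the lower number. Compound 3 gives a limit and no number, so the full size of the step stays unknown: the limit of > 250000 nM in this assay, at which 1 of the 3 values shown sits.

From the compounds shown here alone, whether the aromatic ring itself or its chloro and trifluoromethyl groups carry the difference stays open. Plain phenylamino or dimethylamino on the same carbonyl carbon would separate these.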